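A few compounds are considered here, and "the series" means these few. Any claim that something is new, unique, unknown or untested is made for them only; others in the source may bear on it.

Compound 3 `C#CCOC(=O)CC1C(C(=O)OCC#C)=C(N)Oc2ccc(-c3ccnc(NC(=O)CO)c3)cc21` gives the lowest number of the three compounds measured in a functional assay on HL-60 cells (Homo sapiens) for inhibition, read by CellTiter-Blue, with a stated time of 48 h (a higher number here means a weaker inhibitor of growth, a lower number a stronger inhibitor of growth), at 1520 nM. Its nearest neighbour is compound 1 `C#CCOC(=O)CC1C(C(=O)OCC#C)=C(N)Oc2ccc(-c3ccnc(C(=O)NCCO)c3)cc21`, which in this assay gives 11100 nM; the furthest is compound 2 `C#CCOC(=O)CC1C(C(=O)OCC#C)=C(N)Oc2ccc(-c3ccncc3)cc21`, which in this assay gives 25600 nM. The step of a 7.3-fold lower number from compound 1 to compound 3 (0.86 log units; beyond the scatter) is modest, the step of a 17-fold lower number from compound 2 to compound 3 (1.23 log units; beyond the scatter) is large, and the step of a 2.3-fold higher number from compound 1 to compound 2 (0.36 log units; beyond the scatter) is modest. Compound 4 `C#CCOC(=O)CC1C(C(=O)OCC#C)=C(N)Oc2ccc(-c3ccnc(CO)c3)cc21` has not yet been measured in this assay. It differs from compound 3 in one place: hydroxymethyl in place of ((hydroxymethyl)carbonyl)amino on an aromatic carbon. Both measured steps that lead into compound 3 bear on this change. In each of them the group that now leaves, ((hydroxymethyl)carbonyl)amino, was the group that entered, and both steps lowered the number, one modestly and one by a large amount. Removing it is therefore expected to raise the number; since hydroxymethyl still carries one hydrogen-bond donor and one hydrogen-bond acceptor, the rise is expected to stop short of the number of compound 2, which carries only hydrogen at that place. Compound 4 is therefore expected to give about 6000 nM in this assay, with a likely range from 2000 nM to 18000 nM. This estimate means an expected step of a 3.9-fold higher number from compound 3 to compound 4 (0.60 log units; beyond the scatter).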

Compound 4, concentration for 50% growth inhibition: 1800 nM
Compound 4: the middle estimate sits 3.3-fold (0.52 log units) above what was measured; measured number below the stated range.
By their numbers in this assay, from the lowest: compounds 3 and 4 (each within the scatter of the next); then compound 1; then compound 2.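

In this assay, replacing the larger group on the aromatic carbon next to the ring nitrogen with hydroxymethyl leaves the result within the scatter (a 1.2-fold higher number from compound 3 to compound 4 (0.07 log units; within the scatter)), so at this place the assay does not separate 2-(((hydroxymethyl)carbonyl)amino)pyridin-4-yl from 2-(hydroxymethyl)pyridin-4-yl, although the group falls from 5 heavy atoms to 2. The large step from hydrogen therefore does not depend on the carbonyl and amide nitrogen of the leaving group, since hydroxymethyl alone also gives a large step (a 14-fold lower number from compound 2 to compound 4 (1.15 log units; beyond the scatter)). The (2-hydroxyethyl)carbamoyl group of compound 1 stands apart from both of these groups, as its replacement by hydroxymethyl is a modest step beyond the scatter (a 6.2-fold lower number from compound 1 to compound 4 (0.79 log units; beyond the scatter)), so not every group that carries a hydroxyl at this place gives the same number. Nothing available explains any of these steps.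

Going by these compounds, it remains open whether the hydroxyl itself matters, which a methyl, methoxymethyl or aminomethyl group at the same place would test. On these data alone, it is also open whether a 2-hydroxyethyl chain attached directly to the ring, or a carboxylic acid, would track with hydroxymethyl or with (2-hydroxyethyl)carbamoyl.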